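Cytotoxicity notes: methylamino to propylamino

This account rests on a few compounds, and the source may have more. Where it says the series, first, only, none or still open, it means among the compounds named here.

Measured so far:
compound 1 `Nc1nc(Cl)c(-c2nc3ccccc3s2)c(N[C@@H]2C[C@H](CO)[C@@H](O)[C@H]2O)n1` — 14000 nM
compound 2 `CNc1nc(C)c(-c2nc3ccccc3s2)c(N[C@@H]2C[C@H](CO)[C@@H](O)[C@H]2O)n1` — > 25000 nM (a limit of the assay)

In an ADME assay on cells (Homo sapiens) for cytotoxicity, read by polymerase chain reaction, with a stated time of 3 days (on this read-out higher numbers stand for lower toxicity in this test and lower numbers for higher toxicity in this test), compound 1 gives 14000 nM. For compound 2 the result in this assay is only a limit of the assay, > 25000 nM, so no number is known for it; compound 2 sits at the limit of > 25000 nM in this assay, at which 1 of the 2 values shown sits, the top edge of what is shown. Within the data shown here, compound 1 and compound 2 differ in more than one place, so no single step is drawn between them; their values show only a number for one and a limit for the other.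

Compound 3 `CCCNc1nc(C)c(-c2nc3ccccc3s2)c(N[C@@H]2C[C@H](CO)[C@@H](O)[C@H]2O)n1` differs from compound 2 by ethyl in place of hydrogen on a saturated chain carbon bound to a nitrogen on an aromatic ring. Among the measured compounds shown here, no measured step covers such a change. The expected step in this assay is a step that the limit leaves unreadable from compound 2 to compound 3, none beyond the scatter. Compound 3 is expected at 30000 nM, within 12000 nM to 80000 nM, most likely reported again as a limit.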

Compound 3, half-maximal cytotoxic concentration: > 25000 nM
Compound 3: no number, only a limit (the forecaster's own chance of this, stated with the estimate: 75%); the middle value lies beyond the limit too.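

Among these compounds, compound 2 and compound 3 each give only a limit of the assay in this assay, and no step between them can be read. The compounds shown leave open whether going from methylamino to propylamino changes the read-out at all, and by how much.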